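Isopropyl Substitution on the Amide of an Inactive Lead

This account rests on a few compounds, and the source may have more. Where it says the series, first, only, none or still open, it means among the compounds named here.

The set of compounds shares one core. Compound 1 `CCC1C(=O)N(C)c2cnc(-n3ccc4cc(C(N)=O)ccc43)nc2N1c1ccn(C)n1` carries a primary carboxamide on its fused bicyclic substituent, while compound 2 `CC[C@@H]1C(=O)N(C)c2cnc(Nc3ccc(S(N)(=O)=O)cc3)nc2N1C1CCCC1` and compound 3 `CCC1C(=O)N(C)c2cnc(Nc3ccc(S(=O)(=O)NCCCO)cc3)nc2N1c1ccn(C)n1` carry an anilino group bearing a sulfonamide. In a functional assay on NCI-H1975 cells (Homo sapiens) for antiproliferative activity, read by CCK-8 assay, with a stated time of 72 h (a lower number here means a stronger inhibitor of growth, a higher number a weaker inhibitor of growth), compound 1 is reported as "not active" (no number reported), so no number places it among the others. In this assay, among the measured compounds shown here, compound 2 gives 5290 nM, and in this assay compound 3 gives 25800 nM; both stand in the weak range, and no step between them is given here, so only their two values can be compared.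

Compound 4 `CCC1C(=O)N(C)c2cnc(-n3ccc4cc(C(=O)NC(C)C)ccc43)nc2N1c1ccn(C)n1` has not yet been measured. It differs from compound 1 by one change: isopropyl in place of hydrogen on an amide-type nitrogen. For the measured compounds named here, no measured pair in this set shows this change, so its size cannot be read from any step. Since compound 1 is reported without a number, a direction for the step in this assay cannot be fixed; the expectation is that compound 4 stays weak, with a fair chance that only a limit is again reported. Compound 4 is estimated to give about 20000 nM in this assay, within a range from 4000 nM to 100000 nM.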

Compound 4, concentration for 50% growth inhibition: 12200 nM
Beside the measured number, compound 4's estimate is 1.6-fold (0.21 log units) above it, and the stated range covers the measured number.
By their numbers in this assay, from the lowest: compound 2; then compound 4; then compound 3.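

In this assay, among the compounds shown here, compound 4 gives 12200 nM, while compound 1 is reported as "not active" (no number reported), so no step from compound 1 to compound 4 can be read. The compounds shown leave open how far isopropyl in place of hydrogen on an amide-type nitrogen shifts growth inhibition. No supporting evidence bears on this result.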